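This account rests on a few compounds, and the source may have more. Where it says the series, first, only, none or still open, it means among the compounds named here.

In an in vitro ADME assay on microsomes from liver (Mus musculus) for metabolic stability, read by LC-MS (a lower number here means that the compound disappears faster, a higher number that the compound lasts longer), compound 1 `CON/C(=N\C1=NC(=O)C(=O)N1C(C)C)Nc1ccc(Cl)c(Cl)c1` gives > 1 h, which is a limit. Compound 2 `CN/C(=N\C1=NC(=O)C(=O)N1C(C)C)Nc1ccc(Cl)c(Cl)c1` gives > 1 h, also a limit. Compound 3 `CC(C)N1C(=O)C(=O)N=C1/N=C(\NCc1ccccc1)Nc1ccc(Cl)c(Cl)c1` gives > 1 h, again a limit. Among the measured compounds shown here, the series so far therefore has one shared reading, (the limit of > 1 h in this assay, at which 3 of the 3 values shown sit). Compound 4 `CCCCCCN/C(=N\C1=NC(=O)C(=O)N1C(C)C)Nc1ccc(Cl)c(Cl)c1` differs from compound 2 by pentyl in place of hydrogen on a saturated chain carbon bound to an amine nitrogen, which turns methylamino into hexylamino. The closest measured change is a step that the two limits leave unreadable from compound 2 to compound 3, where phenyl replaces hydrogen at that same place. Likewise, a step that the two limits leave unreadable from compound 1 to compound 2 and a step that the two limits leave unreadable from compound 1 to compound 3 give no size. These steps support no direction in this assay, so the expected change is only a rough estimate: a step that the limit leaves unreadable from compound 2 to compound 4. For compound 4 the expected half-life is 1.2 h, estimated to lie between 0.4 h and 3 h.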

Compound 4, half-life: 0.579 h
Compound 4: middle estimate off by 2.1-fold (0.32 log units), on the high side, within the range that was stated.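

Compound 4, with its hexylamino group, is the only compound shown whose half-life at this amine nitrogen is a number and not a limit: the limit of > 1 h in this assay, at which 3 of the 4 values shown sit. In this assay pentyl in place of hydrogen gives an at least 1.7-fold lower number from compound 2 to compound 4 (0.23 log units; that floor lies within the scatter) while pentyl in place of phenyl gives an at least 1.7-fold lower number from compound 3 to compound 4 (0.23 log units; that floor lies within the scatter) and hexyl in place of methoxy gives an at least 1.7-fold lower number from compound 1 to compound 4 (0.23 log units; that floor lies within the scatter). On these data alone, each is only a floor, and that floor lies within the scatter, so the true size of these steps remains unknown.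

As far as these compounds go, what a propyl chain would give at this place stays open. So does the effect of a hexyl chain ending in a hydroxyl group.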